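Adding a Methyl Next to the Ring Nitrogen

The compounds below may be only part of what the source reports. "The series", "measured", "known", "first", "only" and "open" are said of these compounds alone.

Measured compounds:
compound 1, `Cc1cccc(C)c1NC(=O)Nc1ccncc1`: 30 mg/kg
compound 2, `Cc1cccc(Cl)c1NC(=O)Nc1ccncc1`: 30 mg/kg
compound 3, `Cc1cc(C)c(NC(=O)Nc2ccncc2)c(C)c1`: 30 mg/kg

All three were tested in a functional assay on the whole organism with Mus musculus as the target, in the maximal electroshock model, with a stated time of 30 min; on this read-out lower numbers stand for an effect already at smaller amounts and higher numbers for an effect only at larger amounts of compound. Compound 1 gives 30 mg/kg. Compound 2 differs from compound 1 by chloro in place of methyl on an aromatic carbon, and the step of no change at the digits printed from compound 1 to compound 2 (within the scatter). Compound 3 differs from compound 1 by methyl in place of hydrogen on an aromatic carbon, and the step of no change at the digits printed from compound 1 to compound 3 (within the scatter). Compound 2 thus stands level with compounds 1 and 3 at the digits recorded.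

Compound 4, `Cc1cc(NC(=O)Nc2c(C)cccc2Cl)ccn1`, has not yet been measured in this assay. It differs from compound 2 by methyl in place of hydrogen on an aromatic carbon. Within the data shown here, this is the same kind of change as the one from compound 1 to compound 3, though the surroundings differ: in compound 3 the methyl enters on a six-membered aromatic ring of carbon only, meta to two methyl groups and para to a large group, while in compound 4 it enters on a six-membered aromatic ring with 1 nitrogen, next to the ring nitrogen and meta to a large group. The two cores differ by chloro in place of methyl on an aromatic carbon.

A step of no change at the digits printed from compound 2 to compound 4 (within the scatter) is expected from compound 2 to compound 4, resting on the earlier no change at the digits printed from compound 1 to compound 3 (within the scatter) of the same kind of change. Compound 4 is therefore estimated at 30 mg/kg, with a range from 15 mg/kg to 100 mg/kg.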

Compound 4, minimum effective dose: 30 mg/kg
For compound 4 middle estimate and measured number coincide at the digits printed, and the stated range covers the measured number.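

In this assay, methyl in place of hydrogen on an aromatic carbon, next to the ring nitrogen, gives no change at the digits printed from compound 2 to compound 4 (within the scatter). Among these compounds, this does not show that the change would carry over to every core: only two cores are compared, they differ only by chloro in place of methyl, and the methyl enters a different ring in each pair, so a position-specific effect cannot be separated from the core. Within these limits, the change reads alike on both cores, and neither step shows any movement in the read-out: the same change on two cores in this assay, no change at the digits printed (within the scatter) from compound 1 to compound 3 and no change at the digits printed (within the scatter) from compound 2 to compound 4, 1.0-fold (0.00 log units) apart, within the scatter of two such steps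

The compounds shown leave open how a larger group, such as an ethyl, a methoxy or an amine, would read in that same place next to the ring nitrogen. They also leave open whether the two cores would still stay together in this assay with such a group, since a methyl is the only group shown entering there.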